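Amide to amine in a chemokine receptor antagonist series

The compounds below may be only part of what the source reports. "The series", "measured", "known", "first", "only" and "open" are said of these compounds alone.

The series rests on a shared core bearing a chlorothiophene sulfonamide and a benzyl group with an amide side chain. In a functional assay on CHO cells for antagonist activity at C-C chemokine receptor type 4 (Homo sapiens), read by GTPgammaS binding (a lower number here means a stronger inhibitor, a higher number a weaker inhibitor), compound 1 `CC(=O)NCc1cccc(Cn2nc(NS(=O)(=O)c3ccc(Cl)s3)c3ccccc32)c1` gives 251 nM. Compound 2 `CC(=O)NCc1cccc(Cn2nc(NS(=O)(=O)c3ccc(Cl)s3)c3c(CO)cccc32)c1` gives 6.31 nM, and the step of a 40-fold lower number from compound 1 to compound 2 (1.60 log units; beyond the scatter) is large. Compound 3 `COc1cccc2c1c(NS(=O)(=O)c1ccc(Cl)s1)nn2Cc1cccc(CNC(=O)C2COC2)c1`, which carries a methoxy group on the core and an oxetane amide on the side chain, gives 20 nM in this assay; it stands between compound 2 and compound 1, and both gaps lie beyond the scatter.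

Compound 4 `COc1cccc2c1c(NS(=O)(=O)c1ccc(Cl)s1)nn2Cc1cccc(CNC2COC2)c1` differs from compound 3 in one place: oxetan-3-yl in place of (oxetan-3-yl)carbonyl on an amine nitrogen. Going by the values given here, the only measured step in the set concerns a change on the aromatic core, not on the side chain, so it does not bear on this change. The three measured compounds all carry an amide at that position, and nothing in the set shows how an amine behaves there. Among the compounds with values here, with no direct precedent, only a modest shift is expected, with wide uncertainty. The step from compound 3 to compound 4 is estimated as a 2.0-fold higher number from compound 3 to compound 4 (0.30 log units; within the scatter). Compound 4 is therefore expected to give 40 nM in this assay, within a range from 8 nM to 200 nM.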

Compound 4, half-maximal inhibitory concentration: 251 nM
Beside the measured number, compound 4's estimate is 6.3-fold (0.80 log units) below it; the measured number lies above the stated range.
By their numbers in this assay, from the lowest: compound 2; then compound 3; then compounds 1 and 4 (each within the scatter of the next).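

At this position the side chain responds strongly to the linking group: with the methoxy group held on the core, exchanging (oxetan-3-yl)carbonyl for oxetan-3-yl on the amine nitrogen gives a 13-fold higher number from compound 3 to compound 4 (1.10 log units; beyond the scatter) in this assay and turns the amide into an amine. Going by these compounds alone, the earlier compounds all carried an amide there, and their only one-place step lay on the core, so this pair is the first to show that the side chain can move the number by a large step and that the amide is the form with the lower number here. Nothing given here explains the size of this step.

The pair changes the carbonyl alone, so it leaves open whether a plain methylamine or a cyclobutylamine side chain, or a urea or a sulfonamide in place of the amide, would keep or lose the lower number. It also leaves open whether the same step would appear on a core carrying hydroxymethyl in place of methoxy, or on the core of compound 1, which has neither group.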